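Sulfur substituent series: tert-butyl to benzyl on the cysteine side chain

The source may report more compounds than this note shows. Statements on the series, on what has been measured and on what is new or still open speak of the compounds shown alone.

Compound 1 `COC(=O)N[C@@H](CSC)C(=O)N1CCC[C@H]1c1ncc(-c2ccc(-c3ccc(-c4cnc([C@@H]5CCCN5C(=O)[C@@H](NC(=O)OC)C(C)C)[nH]4)cc3)cc2)[nH]1` and compound 2 `COC(=O)N[C@@H](CSC(C)(C)C)C(=O)N1CCC[C@H]1c1ncc(-c2ccc(-c3ccc(-c4cnc([C@@H]5CCCN5C(=O)[C@@H](NC(=O)OC)C(C)C)[nH]4)cc3)cc2)[nH]1` share one core and differ only in the group on the sulfur. In an ADME assay on PBMC cells (Homo sapiens) for cytotoxicity (on this read-out higher numbers stand for lower toxicity in this test and lower numbers for higher toxicity in this test), compound 1 gives 31000 nM and compound 2 gives 18000 nM. Among the measured compounds shown here, the step of a 1.7-fold lower number from compound 1 to compound 2 (0.24 log units; within the scatter) is the only comparison available, and it leaves compound 2 and compound 1 within the scatter of each other, so neither stands apart from the other on this read-out.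

Compound 3 `COC(=O)N[C@@H](CSCc1ccccc1)C(=O)N1CCC[C@H]1c1ncc(-c2ccc(-c3ccc(-c4cnc([C@@H]5CCCN5C(=O)[C@@H](NC(=O)OC)C(C)C)[nH]4)cc3)cc2)[nH]1` carries the change (benzyl in place of tert-butyl on a sulfur). For the measured compounds named here, the one measured step that bears on it, a 1.7-fold lower number from compound 1 to compound 2 (0.24 log units; within the scatter), covers a change on the same sulfur and stayed within the scatter. Nothing in the two numbers gathered so far shows that a group on this sulfur shifts the read-out beyond the scatter, so a step of no more than the scatter is expected for a 1.1-fold lower number from compound 2 to compound 3 (0.05 log units; within the scatter), direction undetermined.

Compound 3 is therefore estimated at 16000 nM in this assay, with a range of 6000 nM to 40000 nM.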

Compound 3, half-maximal cytotoxic concentration: > 100000 nM
Compound 3: no number, only a limit; the forecaster's own chance of this, stated with the estimate: 15%; middle value at least 6.2-fold (0.79 log units) from the limit.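

Methyl and tert-butyl on the sulfur stayed within the scatter of each other, whereas benzyl shows that a group at this place can move the read-out in this assay beyond the scatter, toward lower toxicity in this test, with an at least 5.5-fold higher number from compound 2 to compound 3 (0.74 log units; beyond the scatter) and an at least 3.2-fold higher number from compound 1 to compound 3 (0.50 log units; beyond the scatter). Compound 3 is recorded as a limit of the assay, > 100000 nM, and not as a number. Of the three sulfur groups, only benzyl, the one with a six-membered aromatic ring, stands apart, and the size of its steps is bounded on one side only: the limit of > 100000 nM in this assay, at which 1 of the 3 values shown sits.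

The compounds shown do not separate the aromatic ring from the size of the group: cyclohexylmethyl on the sulfur would bear on that, while phenyl directly on the sulfur or a longer chain ending in phenyl would test the chain carbon that links benzyl to the sulfur. Also open, as far as these compounds go, is whether the read-out holds with an amine or a carboxylic acid on the benzyl ring.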